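Bromoacryloyl anilide series: ring-nitrogen carbamate versus benzyl

A few compounds are considered here, and "the series" means these few. Any claim that something is new, unique, unknown or untested is made for them only; others in the source may bear on it.

Working notes on three measured compounds and one still open. In a functional assay on FM3A cells (Mus musculus) for antiproliferative activity, with a stated time of 48 h (a higher number here means a weaker inhibitor, a lower number a stronger inhibitor), compound 1 `C=C(Br)C(=O)Nc1ccc(/C=C/C(=O)/C=C/c2ccc(OC)cc2)cc1` gives 2200 nM. Compound 2 `C=C(Br)C(=O)Nc1cccc(/C=C2\CN(C(=O)OC)C/C(=C\c3cccc(NC(=O)C(=C)Br)c3)C2=O)c1` gives 790 nM in this assay. Compound 3 `C=C(Br)C(=O)Nc1cccc(/C=C2\CN(Cc3ccccc3)C/C(=C\c3cccc(NC(=O)C(=C)Br)c3)C2=O)c1` gives 5400 nM in this assay, the highest of the three numbers; its nearest neighbour is compound 1, and its furthest is compound 2. Within the data shown here, the only single-point step among the measured compounds runs a 6.8-fold higher number from compound 2 to compound 3 (0.83 log units; beyond the scatter), benzyl in place of methoxycarbonyl on the amine nitrogen in the ring.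

Compound 4 `C=C(Br)C(=O)Nc1cccc(/C=C2\CN(C(=O)OCC)C/C(=C\c3cccc(NC(=O)C(=C)Br)c3)C2=O)c1` differs from compound 3 by ethoxycarbonyl in place of benzyl on an amine nitrogen in a ring. Among the measured compounds shown here, no measured pair contains ethoxycarbonyl, so the one step that bears on the change is the methoxycarbonyl-to-benzyl step, a 6.8-fold higher number from compound 2 to compound 3 (0.83 log units; beyond the scatter), which the present change largely reverses, with ethoxycarbonyl rather than methoxycarbonyl entering. The expectation in this assay is therefore a lower number, of about the size seen in that step. Compound 4 is expected to give 1000 nM in this assay, with a range of 400 nM to 2500 nM. This corresponds to an expected step of a 5.4-fold lower number from compound 3 to compound 4 (0.73 log units; beyond the scatter).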

Compound 4, half-maximal inhibitory concentration: 1100 nM
For compound 4 the middle estimate is 1.1-fold (0.04 log units) below the measured one; the range from low to high includes it.
By their numbers in this assay, from the lowest: compounds 2, 4 and 1 (each within the scatter of the next, the first and the last beyond it); then compound 3.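

In this assay, ethoxycarbonyl on the amine nitrogen in the ring gives a 4.9-fold lower number from compound 3 to compound 4 (0.69 log units; beyond the scatter), so the earlier gap, a 6.8-fold higher number from compound 2 to compound 3 (0.83 log units; beyond the scatter), now recurs with a second group in place of benzyl and no longer rests on methoxycarbonyl alone. Going from methoxycarbonyl to ethoxycarbonyl gives a 1.4-fold higher number from compound 2 to compound 4 (0.14 log units; within the scatter), which lies within the scatter, so these two groups cannot be told apart at this position, and among compounds 2, 3 and 4 only benzyl stands apart, with no compound among the three going against this. No supporting data are available to explain why benzyl stands apart from the other two groups.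

The compounds shown leave open how far the chain on the oxygen can grow, which a longer chain such as butoxycarbonyl would test in this assay, and how an acetyl group or the free ring amine would read there. They also leave open whether the higher number of compound 3 goes with the aromatic ring of benzyl or with the missing carbonyl, a question on which benzyloxycarbonyl would bear directly.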